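The source may hold more compounds than are shown below. What is called first, only, known or untested is meant among the compounds shown, and "the series" means these compounds.

Compound 1 `COc1cc(OC)n2cc(-c3ccc([N+](=O)[O-])cc3)nc2n1` carries a nitro group. In a functional assay on HT-29 cells (Homo sapiens) for antiproliferative activity, read by MTT assay, with a stated time of 72 h (a lower number here means a stronger inhibitor of growth, a higher number a weaker inhibitor of growth), compound 1 gives > 100000 nM, which is a limit of the assay and not a number. Compound 2 `COc1cc(OC)n2cc(-c3ccc(NCc4ccccc4)cc3)nc2n1` has benzylamino in place of nitro on an aromatic carbon, so the step that the two limits leave unreadable from compound 1 to compound 2 cannot be read. In this assay compound 2 gives > 100000 nM, again a limit rather than a number. Both values sit at the limit of > 100000 nM in this assay, at which 2 of the 2 values shown sit. Compound 3 `COc1cc(OC)n2cc(-c3ccc(N(Cc4ccccc4)Cc4ccccc4)cc3)nc2n1` differs from compound 2 by benzyl in place of hydrogen on a nitrogen on an aromatic ring. Only the unreadable step bears on this change, so no shift beyond the scatter can be foreseen. Compound 3 is expected to give 150000 nM, within 30000 nM to 1000000 nM. The expected step is a step that the limit leaves unreadable from compound 2 to compound 3.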

Compound 3, concentration for 50% growth inhibition: > 100000 nM
Compound 3: only a limit was reported; the forecaster's own chance of this, stated with the estimate: 80%; the middle value lies beyond the limit too.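

Compound 3, like compound 2, gives only a limit and not a number, so no new step can be read between them: the limit of > 100000 nM in this assay, at which 3 of the 3 values shown sit. The compounds shown leave open how compound 1, compound 2 and compound 3 truly rank in this assay.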